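The source may report more compounds than this note shows. Statements on the series, on what has been measured and on what is new or still open speak of the compounds shown alone.

- Compound 1 `C/C(=N\NC(=S)Nc1ccccc1I)c1ccccn1`: 4.1 nM
- Compound 2 `C/C(=N\NC(=S)Nc1ccc(I)cc1)c1ccccn1`: 6.61 nM
- Compound 3 `C/C(=N/NC(=S)Nc1ccccc1I)c1ccccn1`: 4.1 nM

All three numbers come from a functional assay on MCF7 cells (Homo sapiens) for cytotoxicity, read by MTT assay, with a stated time of 48 h; a higher number here means a weaker inhibitor, a lower number a stronger inhibitor. Compound 1 shares its number with compound 3, and compound 2 lies within the usual scatter of both, so these three compounds cannot be ranked. Among the compounds with values here, the only measured step that isolates a single structural feature is no change at the digits printed from compound 1 to compound 3 (within the scatter), and it concerns (the fact that compounds 1 and 3 differ only in the configuration as drawn). A change in how a double bond is drawn therefore made no visible difference here.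

The next compound makes a different kind of change. Compound 4 `C/C(=N\NC(=S)Nc1ccccc1[N+](=O)[O-])c1ccccn1` is built from compound 1 by swapping one substituent: nitro in place of iodo on an aromatic carbon. The rest of the molecule stays the same. Within the data shown here, no measured step replaces the iodo with another group, so the data give only weak guidance on this swap. Compound 1 already gives a very low number at 4.1 nM, so a modest rise seems more likely than a further fall. The expected change is a 2.9-fold higher number from compound 1 to compound 4 (0.47 log units; beyond the scatter), a loose estimate. For compound 4 the estimated value is 12 nM, with an expected range from 3 nM to 60 nM.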

Compound 4, half-maximal inhibitory concentration: 5.7 nM
Compound 4: the middle estimate sits 2.1-fold (0.32 log units) above what was measured; low and high end bracket the measured number.
By their numbers in this assay, from the lowest: compounds 1, 3, 4 and 2 (each within the scatter of the next).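

In this assay, nitro in place of iodo on an aromatic carbon ortho to a large group gives a 1.4-fold higher number from compound 1 to compound 4 (0.14 log units; within the scatter) and so leaves the number effectively where it was. Within the data shown here, until now, the compounds had carried only iodo on this ring, so this is the first sign that the group itself can be replaced: a single iodine atom gives way to a group of one nitrogen and two oxygen atoms, with two hydrogen-bond acceptors, and compounds 1 and 4 still cannot be ranked. Nothing given here explains why such different groups give matching numbers.

The compounds shown leave open whether an amine, a carboxylic acid or a plain hydrogen on this carbon would also keep the number this low. They also leave open whether nitro in place of the iodo of compound 2 would behave the same way, since a single swap at a single place establishes no general rule.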